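Swapping chloro for amino on a purine-like core

This account rests on a few compounds, and the source may have more. Where it says the series, first, only, none or still open, it means among the compounds named here.

In a functional assay on HOP-62 cells (Homo sapiens) for cytotoxicity, read by sulforhodamine B assay, with a stated time of 48 h (on this read-out lower numbers stand for stronger inhibition of growth and higher numbers for weaker inhibition of growth), compound 1, with the structure `ClCc1ccccc1Cn1cnc2c(Cl)nc(Cl)nc21`, gives 2040 nM. This is the lower of the two numbers recorded so far. The other measured compound, compound 2 with the structure `Nc1nc(Cl)c2ncn(Cc3ccc(CCl)cc3)c2n1`, gives 6920 nM in this assay, a higher number, and the gap between the two lies beyond the usual scatter of this measurement. Going by the values given here, no step between compounds that differ in a single place has been measured, so the account has nothing yet to lean on beyond these two values.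

Compound 3, with the structure `Nc1nc(Cl)c2ncn(Cc3ccccc3CCl)c2n1`, has not been measured. Relative to compound 1 it differs as follows: amino in place of chloro on an aromatic carbon. Since compound 2 also carries an amino group in place of a chloro group on the same kind of core and gives 6920 nM, the step is expected to move the number upward, toward weaker inhibition of growth, by an amount that the estimate a 2.5-fold higher number from compound 1 to compound 3 (0.39 log units; beyond the scatter) is meant to express. For compound 3 the expected value in this assay is 5000 nM, with a likely range from 2000 nM to 12000 nM.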

Compound 3, concentration for 50% growth inhibition: 21900 nM
Compound 3: the middle estimate sits 4.4-fold (0.64 log units) below what was measured; the measured number lies above the stated range.
By their numbers in this assay, from the lowest: compound 1; then compound 2; then compound 3.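

In this assay, amino in place of chloro on an aromatic carbon, at the place between two ring nitrogen atoms, gives an 11-fold higher number from compound 1 to compound 3 (1.03 log units; beyond the scatter), a large step that lies well beyond the scatter. Going by these compounds alone, this is the first comparison in which only one place differs, so the loss of growth inhibition can be tied to this exchange alone, with the rest of compound 1 left as it stands. At this position, then, chloro is clearly preferred over amino on this read-out, though nothing here gives a measured property that would account for the size of the step.

As far as these compounds go, what remains open is whether the loss belongs to amino specifically or would also follow with another group at this place, such as methylamino, methoxy or a plain hydrogen. From the compounds shown here alone, it is also open whether the same exchange would carry a step of similar size at the chloro group that stays on the core, or on a core bearing a different substituent on its ring nitrogen.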